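The source may hold more compounds than are shown below. What is called first, only, known or untested is meant among the compounds shown, and "the series" means these compounds.

Measured compounds: compound 1 `Fc1ccc(-c2ccc3c(NCCCNCc4ccco4)ccnc3c2)cc1`, 237 10^-6 cm/s in an ADME assay for permeability, using PAMPA, with a stated time of 30 min, at pH 7.4; a higher number here means that the compound crosses the layer faster, a lower number that the compound crosses the layer more slowly; compound 2 `CC(C)CCc1ccc2c(NCCCNCc3ccco3)ccnc2c1`, 23 10^-6 cm/s; compound 3 `FC(F)(F)c1ccc(-c2ccc3c(NCCCNCc4ccco4)ccnc3c2)cc1`, 237 10^-6 cm/s.

Compound 1 stands level with compound 3, the two together the highest of the three numbers, since no change at the digits printed from compound 1 to compound 3 (within the scatter); compound 2 sits well apart, as a 10-fold lower number from compound 1 to compound 2 (1.01 log units; beyond the scatter). Compound 4 `COc1ccc(F)cc1CNCCCNc1ccnc2cc(-c3ccc(F)cc3)ccc12` differs from compound 1 in one place: 5-fluoro-2-methoxyphenyl in place of furan-2-yl on a saturated chain carbon bound to an amine nitrogen. None of the three measured steps touches this place; all of them change the group on the aromatic carbon of the shared core. Among the compounds with values here, the only step among them that swaps one small group for another, no change at the digits printed from compound 1 to compound 3 (within the scatter), stayed within the scatter, whereas a 10-fold lower number from compound 1 to compound 2 (1.01 log units; beyond the scatter) was large. Within the data shown here, with no direct precedent, compound 4 is expected to remain near compound 1 in this assay. The expected step is a 1.3-fold lower number from compound 1 to compound 4 (0.12 log units; within the scatter). Compound 4 is thus estimated at 180 10^-6 cm/s, within 80 10^-6 cm/s to 400 10^-6 cm/s.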

Compound 4, apparent permeability: 237 10^-6 cm/s
Compound 4: middle estimate off by 1.3-fold (0.12 log units), on the low side; low and high end bracket the measured number.
By their numbers in this assay, from the lowest: compound 2; then compounds 1, 3 and 4 (each within the scatter of the next).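

Within the data shown here, the earlier steps all changed the group on the aromatic carbon of the shared core, whereas this is the first step on a saturated chain carbon bound to an amine nitrogen, and in this assay it gives no change at the digits printed from compound 1 to compound 4 (within the scatter). With 4-fluorophenyl on the core, furan-2-yl and 5-fluoro-2-methoxyphenyl therefore read alike at this place. Nothing given here bears on why the number holds. From the compounds shown here alone, it remains open whether a carboxylic acid or an amine at this place would read the same, and whether this exchange would hold with the isopentyl group of compound 2 on the core.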